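Removing bromo on two related cores: working notes

The compounds below may be only part of what the source reports. "The series", "measured", "known", "first", "only" and "open" are said of these compounds alone.

Measured so far:
compound 1 `Cc1ccc(N2C(=O)CS/C2=N/N=C/c2c[nH]c3ccc(Br)cc23)cc1` gives 98500 nM
compound 2 `S=C(N/N=C/c1c[nH]c2ccc(Br)cc12)Nc1cccc2ccccc12` gives 1600 nM
compound 3 `S=C(N/N=C/c1c[nH]c2ccccc12)Nc1cccc2ccccc12` gives 210 nM

In a functional assay on OVCAR-3 cells (Homo sapiens) for inhibition, read by spectrophotometry and sulforhodamine B assay, with a stated time of 48 h (on this read-out higher numbers stand for weaker inhibition of growth and lower numbers for stronger inhibition of growth), compound 1 stands highest of the three numbers, well beyond the scatter from both compound 2 and compound 3. Compound 1 and compound 2 differ in more than one place; the difference between the two cores is not broken down here, so nothing is read from their gap.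

Compound 2 and compound 3 differ in one place only: hydrogen in place of bromo on an aromatic carbon. That change gives a 7.6-fold lower number from compound 2 to compound 3 (0.88 log units; beyond the scatter).

Compound 4 `Cc1ccc(N2C(=O)CS/C2=N/N=C/c2c[nH]c3ccccc23)cc1` is not yet measured. It stands to compound 1 as compound 3 stands to compound 2: hydrogen in place of bromo on an aromatic carbon. The place is the same word for word, so this is the same change, now on the core of compound 1.

Within the data shown here, the expectation for compound 4 is a step of a 3.9-fold lower number from compound 1 to compound 4 (0.60 log units; beyond the scatter) from compound 1, which rests on the step seen for the same change, a 7.6-fold lower number from compound 2 to compound 3 (0.88 log units; beyond the scatter), with only one example and a different core behind it, so the range is kept wide. Compound 4 is estimated at 25000 nM, between 6000 nM and 100000 nM.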

Compound 4, concentration for 50% growth inhibition: > 100000 nM
Compound 4: only a limit was reported; the forecaster's own chance of this, stated with the estimate: 15%; at least 4.0-fold (0.60 log units) between middle value and limit.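

In this assay compound 4 gives > 100000 nM, which is a limit of the assay and not a number: the limit of > 100000 nM in this assay, at which 1 of the 4 values shown sits.

Hydrogen in place of bromo on an aromatic carbon gives an at least 1.0-fold higher number from compound 1 to compound 4 (0.00 log units; that floor lies within the scatter), so the lower number seen on the other core does not carry over to the core of compound 1, and the change cannot be transferred between these two cores as a fixed step: the same change on two cores in this assay, a 7.6-fold lower number (0.88 log units; beyond the scatter) from compound 2 to compound 3 and an at least 1.0-fold higher number (0.00 log units; that floor lies within the scatter) from compound 1 to compound 4, at least 7.7-fold (0.88 log units) apart, beyond the scatter of two such steps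

This does not show the true size of the step on the core of compound 1, which has a floor only, and one pair on each core gives no rule for the series as a whole.

The compounds shown leave open how a fluoro, a methoxy or an amine in place of bromo would read on either core. Also open, on these data alone, is which of the several differences between the two cores sets the split between the two steps.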